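Swapping the aryl group on a hydrazone-urea quinoline series

The compounds below may be only part of what the source reports. "The series", "measured", "known", "first", "only" and "open" are said of these compounds alone.

Three compounds have been measured in a functional assay on HT-29 cells (Homo sapiens) for cytotoxicity, read by MTT assay, with a stated time of 72 h; a lower number here means a stronger inhibitor, a higher number a weaker inhibitor:
compound 1, `COc1cc2c(Oc3ccc(NC(=O)N/N=C/c4ccc([N+](=O)[O-])cc4)cc3F)ccnc2cc1OCCCN1CCCC1`, gives 310 nM
compound 2, `COc1cc2c(Oc3ccc(NC(=O)N/N=C/c4ccc(F)cc4Cl)cc3F)ccnc2cc1OCCCN1CCCCC1`, gives 260 nM
compound 3, `COc1cc2c(Oc3ccc(NC(=O)N/N=C/c4ccc([N+](=O)[O-])cc4)cc3F)ccnc2cc1OCCCN1CCC(C)CC1`, gives 230 nM

Compound 3 stands at the lower end of the three numbers, but all three lie close together. Among the compounds with values here, the only single change measured, a 1.3-fold lower number from compound 1 to compound 3 (0.13 log units; within the scatter), shows that exchanging the ring on the chain hardly moves the result. Compound 2 and compound 3 differ in two places at once, so their values can only be noted side by side, and they sit within the scatter of each other.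

Compound 4, `COc1cc2c(Oc3ccc(NC(=O)N/N=C/c4ccc(F)cc4Cl)cc3F)ccnc2cc1OCCCN1CCC(C)CC1`, is compound 3 with one change: 2-chloro-4-fluorophenyl in place of 4-nitrophenyl on a carbon with a double bond to nitrogen. Within the data shown here, no measured step isolates this swap. Compound 2, which carries the same 2-chloro-4-fluorophenyl group, and compound 1, which carries the 4-nitrophenyl group, give values within the scatter of each other, though their chain rings also differ. On that basis the step of a 1.0-fold higher number from compound 3 to compound 4 (0.02 log units; within the scatter) is expected to stay within the scatter, with no clear direction. Compound 4 is therefore estimated at 240 nM, with a likely range from 110 nM to 520 nM.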

Compound 4, half-maximal inhibitory concentration: 440 nM
For compound 4 the middle estimate is 1.8-fold (0.26 log units) below the measured one; measured number inside the range.
By their numbers in this assay, from the lowest: compounds 3, 2, 1 and 4 (each within the scatter of the next).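

Within the data shown here, the step of a 1.9-fold higher number from compound 3 to compound 4 (0.28 log units; within the scatter) is the first direct reading of this swap on a carbon with a double bond to nitrogen, made with the 4-methylpiperidin-1-yl ring held fixed, and in this assay it stays inside the scatter. Among these compounds, the step of a 1.7-fold higher number from compound 2 to compound 4 (0.23 log units; within the scatter) adds a first reading of methyl in place of hydrogen on a saturated ring carbon, and it also stays inside the scatter, so neither single change in these compounds separates from the noise. No evidence is available that explains these numbers.

As far as these compounds go, both aryl groups here are substituted phenyl rings, so it remains open how a plain phenyl, a pyridine ring or a methoxyphenyl group would read at this position. Also open, from the compounds shown here alone, is whether the same aryl swap would read alike with the pyrrolidine or piperidine ring on the chain.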